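Pyridin-2-yl in place of hydroxy: compound 1 to compound 4

The source may hold more compounds than are shown below. What is called first, only, known or untested is meant among the compounds shown, and "the series" means these compounds.

In a functional assay on KB cells (Homo sapiens) for inhibition, read by MTT assay, with a stated time of 24 h, tested at 1 ug/mL (a higher number here means more inhibition of growth at the concentration tested, a lower number less inhibition of growth), compound 1 (`O=C(CCCCC(S)CCS)NO`) gives 10.6%. Compound 3 (`COc1ccc(NC(=O)CCCCC(S)CCS)cc1`) gives 2.49%, which lies within the scatter of the value for compound 1, so neither can be ranked over the other. Compound 2 (`O=C(CCCCC1CCSS1)Nc1ccc([N+](=O)[O-])c(C(F)(F)F)c1`) is reported only as "not active" (no number reported), with no number.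

Compound 4 (`O=C(CCCCC(S)CCS)Nc1ccccn1`), still unmeasured, carries pyridin-2-yl in place of hydroxy on an amide-type nitrogen. Within the data shown here, no measured pair isolates this kind of change. Compound 3 also lacks the hydroxy there and gives 2.49%, so no step beyond the scatter is expected in this assay. The estimated step is small, a number 4.6 percentage points lower from compound 1 to compound 4 (within the scatter). Compound 4 is expected to give 6%, with an estimated range of 0% to 18%.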

Compound 4, percent growth inhibition at one concentration: "not active" (no number reported)
Nothing numeric was reported for compound 4; there is nothing to compare the estimate with.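

Among these compounds, compound 4 is reported as "not active" without a number, so no step from compound 1 to compound 4 can be read. Nothing shown offers an explanation for this result. The compounds shown leave open how far pyridin-2-yl in place of hydroxy shifts the read-out in this assay.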